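Methoxy removal on the pendant phenyl of compound 2

The source may report more compounds than this note shows. Statements on the series, on what has been measured and on what is new or still open speak of the compounds shown alone.

Two members of the series have numbers in a functional assay on HCC 2998 cells (Homo sapiens) for inhibition, read by sulforhodamine B assay, with a stated time of 48 h; a lower number here means a stronger inhibitor of growth, a higher number a weaker inhibitor of growth. Compound 1 `COc1ccc(-c2[nH]c3ccccc3c2/C=C(\C#N)S(=O)(=O)c2ccccc2)cc1` gives 1200 nM. Among the compounds with values here, compound 2 `COc1ccc(-c2[nH]c3ccc(OC)cc3c2/C=C(\C#N)S(=O)(=O)c2ccccc2)cc1` gives 2000 nM, the higher of the two values; the only step so far, a 1.7-fold higher number from compound 1 to compound 2 (0.22 log units; within the scatter), adds a methoxy to the shared core and stays within the scatter.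

Compound 3 `COc1ccc2[nH]c(-c3ccccc3)c(/C=C(\C#N)S(=O)(=O)c3ccccc3)c2c1` is the next change from compound 2: hydrogen in place of methoxy on an aromatic carbon, so the 4-methoxyphenyl becomes a plain phenyl. Within the data shown here, no measured pair addresses this position directly. Among the measured compounds shown here, the only step available concerns a methoxy at a different place on the shared core, and there a 1.7-fold higher number from compound 1 to compound 2 (0.22 log units; within the scatter) did not move the number beyond the scatter. Absent any evidence that a methoxy on either ring matters, the expectation is that removing this one also produces no step beyond the scatter in this assay, with no direction favoured.

On that basis compound 3 is estimated at 1800 nM, within 700 nM to 4500 nM, the expected step from compound 2 to compound 3 being a 1.1-fold lower number from compound 2 to compound 3 (0.05 log units; within the scatter).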

Compound 3, concentration for 50% growth inhibition: 18700 nM
For compound 3 the middle estimate is 10-fold (1.02 log units) below the measured one, outside the stated range (above it).
By their numbers in this assay, from the lowest: compounds 1 and 2 (each within the scatter of the next); then compound 3.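

In this assay, within the data shown here, this is the first change to move the number beyond the scatter: hydrogen in place of methoxy on the aromatic carbon para to a large group, the 4-methoxyphenyl to phenyl change, gives a 9.4-fold higher number from compound 2 to compound 3 (0.97 log units; beyond the scatter) and so ties growth inhibition in this pair to the methoxy at this place. The two methoxy groups therefore do not read alike, since adding the one on the shared core gives a 1.7-fold higher number from compound 1 to compound 2 (0.22 log units; within the scatter) and stays within the scatter, while removing this one does not, and compound 3 keeps the core methoxy throughout. Nothing at hand accounts for the size of the step.

Open, from the compounds shown here alone, is whether the same step would appear on the core of compound 1, which carries no second methoxy. Also open, going by these compounds, is whether an ethoxy, a hydroxyl or an amine at this place on the phenyl would hold the number near that of compound 2, or whether the effect belongs to methoxy alone.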